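Fluorophenyl replacement on the shared core: compound 3 outlook

A few compounds are considered here, and "the series" means these few. Any claim that something is new, unique, unknown or untested is made for them only; others in the source may bear on it.

Measured so far:
compound 1 `Nc1ncnn2c([C@@H]3O[C@H](CO)[C@@H](O)[C@H]3O)cc(C#Cc3ccc(F)cc3)c12` — 89000 nM
compound 2 `Nc1ncnn2c([C@@H]3O[C@H](CO)[C@@H](O)[C@H]3O)cc(-c3ccc(F)cc3)c12` — > 100000 nM

In a functional assay on Z-138 cells (Homo sapiens) for antiproliferative activity, with a stated time of 72 h (a lower number here means a stronger inhibitor, a higher number a weaker inhibitor), compound 1 gives 89000 nM. Compound 2 reaches only a limit of the assay, > 100000 nM. For the measured compounds named here, compound 1 thus stands as the only compound of the pair with a number in this assay; the other value is a limit.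

The unmeasured compound 3 `Nc1ncnn2c([C@@H]3O[C@H](CO)[C@@H](O)[C@H]3O)cc(-c3ccccc3F)c12` differs from compound 1 as follows: 2-fluorophenyl in place of 2-(4-fluorophenyl)ethynyl on an aromatic carbon. Going by the values given here, the one measured step that bears on this is an at least 1.1-fold higher number from compound 1 to compound 2 (0.05 log units; that floor lies within the scatter); the step to compound 3 removes the same ethynyl link but places the fluorine differently on the ring. Going by these compounds, that measured step rests on (the limit of > 100000 nM in this assay, at which 1 of the 2 values shown sits), so its true size is unknown.

Compound 3 is expected to sit at 150000 nM, with a range of 50000 nM to 500000 nM. The expected step is a 1.7-fold higher number from compound 1 to compound 3 (0.23 log units; within the scatter), weaker than compound 1 and likely a limit.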

Compound 3, half-maximal inhibitory concentration: 95300 nM
Compound 3: the middle estimate sits 1.6-fold (0.20 log units) above what was measured, and the stated range covers the measured number.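

Replacing 2-(4-fluorophenyl)ethynyl with 2-fluorophenyl on this aromatic carbon gives, in this assay, a 1.1-fold higher number from compound 1 to compound 3 (0.03 log units; within the scatter), so a directly attached fluorophenyl ring without the triple bond now has a number that cannot be told apart from that of the ethynyl compound. Moving the fluorine gives an at least 1.0-fold lower number from compound 2 to compound 3 (0.02 log units; that floor lies within the scatter), and this figure is only a floor. Compound 2 stands at a limit, so the true size of that step remains unknown: the limit of > 100000 nM in this assay, at which 1 of the 3 values shown sits.

All the compounds shown carry a fluorinated benzene ring at this position, so it remains open whether a small amine, a carboxylic acid or a longer alkyl chain there would change the number in this assay. Going by these compounds, it is also open whether a 2-(2-fluorophenyl)ethynyl group would match compound 1.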